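This account rests on a few compounds, and the source may have more. Where it says the series, first, only, none or still open, it means among the compounds named here.

Compound 1 `Clc1ccc(Nc2nccs2)cc1OCc1ccsc1`: 38000 nM
Compound 2 `Clc1ccc(Nc2nccs2)cc1OCc1nccs1`: 20000 nM
Compound 3 `CC/C(C)=C\COc1cc(Nc2nccs2)ccc1Cl`: 18000 nM

In a functional assay on MT2 cells (Homo sapiens) for cytotoxicity, read by MTT assay (a higher number here means that more compound is tolerated, a lower number that less compound is tolerated), compound 3 gives 18000 nM. It sits within the scatter of compound 2, as a 1.1-fold lower number from compound 2 to compound 3 (0.05 log units; within the scatter) shows, and lies modestly beyond the scatter from compound 1, as a 2.1-fold lower number from compound 1 to compound 3 (0.32 log units; beyond the scatter) shows.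

The next structure is compound 4 `Clc1ccc(Nc2nccs2)cc1OCC1=CCCC1`. The change is cyclopent-1-en-1-yl in place of 2-methylbut-1-en-1-yl on a saturated chain carbon bound to an oxygen on an aromatic ring.

Among the measured compounds shown here, no measured step covers this exact exchange, but all three measured steps alter the same place. They are small: a 1.9-fold lower number from compound 1 to compound 2 (0.28 log units; within the scatter) stays within the scatter, and the largest, a 2.1-fold lower number from compound 1 to compound 3 (0.32 log units; beyond the scatter), only just passes it. A step beyond the scatter in this assay is therefore not expected, and no direction can be called.

The estimated change is a 1.1-fold higher number from compound 3 to compound 4 (0.05 log units; within the scatter).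

Compound 4 is expected at about 20000 nM, with an estimated range of 10000 nM to 38000 nM.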

Compound 4, half-maximal cytotoxic concentration: 15000 nM
Estimate against measurement, compound 4: 1.3-fold (0.12 log units) above; the range from low to high includes it.
By their numbers in this assay, from the lowest: compounds 4, 3, 2 and 1 (each within the scatter of the next, the first and the last beyond it).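

In this assay, replacing 2-methylbut-1-en-1-yl with cyclopent-1-en-1-yl, which has the same count of 5 heavy atoms but adds a five-membered ring of carbon only, stays within the scatter (a 1.2-fold lower number from compound 3 to compound 4 (0.08 log units; within the scatter)), and the step from the thiazole is also within it (a 1.3-fold lower number from compound 2 to compound 4 (0.12 log units; within the scatter)). Thus, a ring of carbon only at this place reads like the open alkenyl group and the 1,3-thiazol-2-yl group, while only the step from the thiophen-3-yl group passes the scatter, and modestly (a 2.5-fold lower number from compound 1 to compound 4 (0.40 log units; beyond the scatter)). Nothing available explains these small differences.

As far as these compounds go, whether an amine, a carboxylic acid or a longer chain on this saturated chain carbon would give a larger step remains open. So does whether saturated cyclopentyl would read like cyclopent-1-en-1-yl.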